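From compound 3 to compound 4: one fluorinated group exchanged

The source may report more compounds than this note shows. Statements on the series, on what has been measured and on what is new or still open speak of the compounds shown alone.

Measured so far in a functional assay on CWR22R cells (Homo sapiens) for antiproliferative activity, read by propidium iodide staining, with a stated time of 96 h (a higher number here means a weaker inhibitor, a lower number a stronger inhibitor), for three compounds:
compound 1 `CC(O)(CSc1cccc(S(F)(F)(F)(F)F)c1)C(=O)Nc1ccc([N+](=O)[O-])cc1C(F)(F)F` gives 17500 nM
compound 2 `CC(O)(COc1cccc(S(F)(F)(F)(F)F)c1)C(=O)Nc1ccc(S(F)(F)(F)(F)F)cc1` gives 17600 nM
compound 3 `CC(O)(COc1cccc(S(F)(F)(F)(F)F)c1)C(=O)Nc1ccc(C(F)(F)F)cc1` gives 15800 nM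

Of the three, compound 3 at 15800 nM lies within the scatter of compound 1 and compound 2. Compound 4 `CC(O)(COc1cccc(C(F)(F)C(F)(F)F)c1)C(=O)Nc1ccc(C(F)(F)F)cc1` differs from it by a group of 7 heavy atoms (2 carbon, 5 fluorine; no ring) in place of a group of 6 heavy atoms (5 fluorine, 1 sulfur; no ring), on an aromatic carbon as 1,1,2,2,2-pentafluoroethyl enters, meta to a large group. For the measured compounds named here, one measured step bears on this: a 1.1-fold lower number from compound 2 to compound 3 (0.05 log units; within the scatter) when the same departing group gave way to a smaller one on another aromatic carbon. Going by the values given here, no measured step brings in 1,1,2,2,2-pentafluoroethyl itself. In this assay no step beyond the scatter is therefore expected. The estimate means a 1.0-fold higher number from compound 3 to compound 4 (0.01 log units; within the scatter) as the expected step. Compound 4 is estimated at 16000 nM with an expected range from 9000 nM to 28000 nM for repeated measurements.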

Compound 4, half-maximal inhibitory concentration: 3600 nM
Estimate against measurement, compound 4: 4.4-fold (0.65 log units) above; measured number outside the range, below it.
By their numbers in this assay, from the lowest: compound 4; then compounds 3, 1 and 2 (each within the scatter of the next).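

At this aromatic carbon, meta to a large group, the exchange moves the number in this assay: there is a 4.4-fold lower number from compound 3 to compound 4 (0.64 log units; beyond the scatter) as 1,1,2,2,2-pentafluoroethyl enters. The same departing group left another aromatic carbon with a 1.1-fold lower number from compound 2 to compound 3 (0.05 log units; within the scatter), so the exchange of this group does not always leave the number unchanged, although place and entering group both differ between the two steps. Nothing measured here accounts for the step.

As far as these compounds go, whether a longer perfluoroalkyl chain or a nitrile on this carbon would lower the number further remains open. So does whether 1,1,2,2,2-pentafluoroethyl gives a similar step with the other side of the molecule changed.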